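The compounds below may be only part of what the source reports. "The series", "measured", "known", "first", "only" and "open" are said of these compounds alone.

Values in an ADME assay on S9 fraction from liver (Mus musculus, strain CD-1) for metabolic stability, read by LC-MS, using NADPH, with stated times of 5 min and 60 min, tested at 5 uM; a lower number here means that less of the compound is left, a higher number that more of the compound is left:
Compound 1 `COc1ccc(COc2ccc(C3CN(C(=O)c4cc(OCCO)ccn4)C3)cc2OC)cc1`: 48%
Compound 2 `COc1cc(C2CN(C(=O)c3cc(OC[C@H](O)CO)ccn3)C2)ccc1OCc1ccc(C2CC2)cc1`: 67%

Compound 1 gives 48% and compound 2 gives 67%. Compound 2 stands highest of the two, and the gap between them lies beyond the scatter. These two compounds differ in more than one place, so their gap does not isolate any single change.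

Next in the series is compound 3 `COc1cc(C2CN(C(=O)c3cc(OCCCC(=O)O)ccn3)C2)ccc1OCc1ccc(C2CC2)cc1`. The change is 2-carboxyethyl in place of 1,2-dihydroxyethyl on a saturated chain carbon bound to an oxygen on an aromatic ring, the rest of the structure staying as it is. Among the measured compounds shown here, no measured pair covers this change, so the expectation is weakly founded: a small upward step in this assay, not clearly beyond the scatter. The expected step is a number 6 percentage points higher from compound 2 to compound 3 (within the scatter). Compound 3 is expected at 73%, with an estimated range from 52% to 90%.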

Compound 3, percent of the compound remaining: 88%
Estimate against measurement, compound 3: 15 percentage points below, within the range that was stated.
By their numbers in this assay, from the lowest: compound 1; then compound 2; then compound 3.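

In this assay, among the compounds shown here, 3-carboxypropoxy in place of 2,3-dihydroxypropoxy gives a number 21 percentage points higher from compound 2 to compound 3 (beyond the scatter), the first change that can be read at a single place. It shows that the group on this saturated chain carbon bound to an oxygen on an aromatic ring can by itself shift the percent remaining, with the shared core unchanged. Nothing available bears on what lies behind this step.

The compounds shown leave open whether the step belongs to the carboxylic acid itself, to the chain that carries it, or to the loss of the two hydroxyl groups and the defined stereocentre. A methyl ester, a primary amide, an amine or a longer chain ending in a carboxylic acid at this place would help to separate these readings.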